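Para cyano in place of trifluoromethyl: a writhing-test step

The source may hold more compounds than are shown below. What is called first, only, known or untested is meant among the compounds shown, and "the series" means these compounds.

The compounds measured so far:
compound 1, `Fc1cccc(COc2nc3ccccc3s2)c1`: 51.9%
compound 2, `Brc1ccc(OCCOc2nc3ccccc3s2)cc1`: 68.6%
compound 3, `FC(F)(F)c1ccc(COc2nc3ccccc3s2)cc1`: 99.6%

These three share one core and were tested in a functional assay on the whole organism with Mus musculus as the target, in the writhing test, at a dose of 100 mg/kg by the intraperitoneal route; on this read-out higher numbers stand for more inhibition at the one dose given (going by the name of the read-out) and lower numbers for less inhibition. Compound 3 stands highest of the three; the gap to compound 2 and the larger gap to compound 1 both lie beyond the usual scatter of this assay, so compound 3 has the highest number of the measured set.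

Compound 4, `N#Cc1ccc(COc2nc3ccccc3s2)cc1`, has not yet been measured. It differs from compound 3 in one place: cyano in place of trifluoromethyl on an aromatic carbon. Among the compounds with values here, no step between two measured compounds tells what this exchange does, so the expectation rests on the numbers alone. Because compound 3 gives 99.6%, a reading near the top of the scale, the step is expected to go downward rather than up, by an amount that may be beyond the scatter: the step from compound 3 to compound 4 is estimated at a number 24.6 percentage points lower from compound 3 to compound 4 (beyond the scatter). Compound 4 is therefore expected to give about 75%, within a range from 45% to 100%.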

Compound 4, a percentage reported as inhibition, in the whole organism at one dose (the size of the read-out at that dose, not a potency): "not active" (no number reported)
The entry for compound 4 holds no number; no gap can be computed for the estimate.
By their numbers in this assay, from the lowest: compound 1; then compound 2; then compound 3.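

Within the data shown here, compound 4 is reported as not active in this assay with no number, so no step from compound 3 to compound 4 can be read. No measurement shown explains this result. The compounds shown leave open how large the effect of cyano in place of trifluoromethyl is.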